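Swapping the acid-bearing ring on a hydroxy core

The source may report more compounds than this note shows. Statements on the series, on what has been measured and on what is new or still open speak of the compounds shown alone.

Three compounds share a core carrying a four-carbon linker that ends in an aryl ether bearing a carboxylic acid. Compound 1, `Cc1c(OCCCCOc2ccc(C(=O)O)c(Cl)c2)ccc(C(=O)CC(C)C)c1C`, is the starting point. In an assay on HEK293 cells for positive allosteric modulation of metabotropic glutamate receptor 3 (Rattus norvegicus), read by thallium flux, with a stated time of 2.5 min (a lower number here means a smaller maximal response, a higher number a larger maximal response), compound 1 gives 12%. Compound 2, `Cc1c(OCCCCOc2ccccc2C(=O)O)ccc(C(=O)CC(C)C)c1C`, differs from compound 1 by 2-carboxyphenyl in place of 4-carboxy-3-chlorophenyl on an oxygen on a saturated carbon. In this assay compound 2 gives 30.7%, and the step of a number 18.7 percentage points higher from compound 1 to compound 2 (beyond the scatter). Compound 3, `Cc1c(OCCCCOc2ccc(C(=O)O)c(Cl)c2)ccc(C(=O)CC(C)C)c1O`, differs from compound 1 by hydroxy in place of methyl on an aromatic carbon; in this assay compound 3 gives 49.5%, and the step of a number 37.5 percentage points higher from compound 1 to compound 3 (beyond the scatter), so compound 3 shows the largest maximal response of the three measured compounds.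

Compound 4, `Cc1c(OCCCCOc2ccccc2C(=O)O)ccc(C(=O)CC(C)C)c1O`, has not been measured. It differs from compound 3 by 2-carboxyphenyl in place of 4-carboxy-3-chlorophenyl on an oxygen on a saturated carbon. This is the same change as that from compound 1 to compound 2, made here on the hydroxy core instead of the methyl core; the place where it occurs is described in identical words for both pairs. Since the change from compound 1 to compound 2 gave a number 18.7 percentage points higher from compound 1 to compound 2 (beyond the scatter), a similar upward step is expected for compound 4, tempered slightly because compound 3 already stands at 49.5% and a maximal response cannot keep growing indefinitely. The step expected from compound 3 to compound 4 in this assay is a number 15.5 percentage points higher from compound 3 to compound 4 (beyond the scatter). For compound 4 the estimated value in this assay is 65%, expected to lie between 48% and 85%.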

Compound 4, largest response reached (reported as percent of maximum), in percent of the reference or control that the assay uses: 28.1%
The estimate for compound 4 lay 36.9 percentage points above the measured number, and the stated range ends above it.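

In this assay, putting 2-carboxyphenyl in place of 4-carboxy-3-chlorophenyl gave a number 21.4 percentage points lower from compound 3 to compound 4 (beyond the scatter), so the swap that raised the response on the core of compound 1 lowered it on the core of compound 3: the same change on two cores in this assay, a number 18.7 percentage points higher (beyond the scatter) from compound 1 to compound 2 and a number 21.4 percentage points lower (beyond the scatter) from compound 3 to compound 4, 40.1 percentage points apart, beyond the scatter of two such steps

The other change did not carry over either, since hydroxy in place of methyl gave a number 2.6 percentage points lower from compound 2 to compound 4 (within the scatter), which leaves no measurable effect of that change when the 2-carboxyphenyl group is present: the same change on two cores in this assay, a number 37.5 percentage points higher (beyond the scatter) from compound 1 to compound 3 and a number 2.6 percentage points lower (within the scatter) from compound 2 to compound 4, 40.1 percentage points apart, beyond the scatter of two such steps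

Among these four compounds, then, the effect of each change depends on the group present at the other place, so a step measured on one core was a poor guide to the same step on the other, but the numbers do not show why this happens or whether it holds beyond these compounds.

The swap alters two things at once, the chlorine and the place of the carboxylic acid, and a 4-carboxyphenyl group on each core would help to separate them. As far as these compounds go, it also remains open how the two cores would respond to other changes, such as a longer chain in place of the four-carbon linker or a methoxy group in place of the hydroxy.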